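The source may report more compounds than this note shows. Statements on the series, on what has been measured and on what is new or still open speak of the compounds shown alone.

Working notes on the shared core in a functional assay for activation of Alpha-1B adrenergic receptor (Homo sapiens), read by calcium flux; on this read-out higher numbers stand for an effect only at larger amounts of compound and lower numbers for an effect already at smaller amounts. Compound 1 `CCN(CC)C(=O)c1ccccc1OCC1=NCCN1` returns only a limit of the assay, < 5020 nM. Compound 2 `c1ccc(-c2ccncc2)c(OCC2=NCCN2)c1` likewise returns only a limit, < 100000 nM. Compound 3 `c1cnc(-c2ccccc2OCC2=NCCN2)nc1` also returns only a limit, < 100000 nM, so its standing is no more than a range; the limit of < 100000 nM in this assay, at which 2 of the 3 values shown sit, holds two of the three values and the limit of < 5020 nM in this assay, at which 1 of the 3 values shown sits, the third. The step that the two limits leave unreadable from compound 2 to compound 3 lies between two limits and cannot be sized. Compound 4 `c1ccc(-c2ccncn2)c(OCC2=NCCN2)c1` differs from compound 3 by pyrimidin-4-yl in place of pyrimidin-2-yl on an aromatic carbon. Going by the values given here, no measured step bears on this change with a readable size, so nothing beyond the scatter is expected in either direction. The step that the limit leaves unreadable from compound 3 to compound 4 is therefore an estimate resting on the limits alone. Compound 4 is expected at 30000 nM, within 3000 nM to 100000 nM.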

Compound 4, half-maximal effective concentration: < 100000 nM
Compound 4: a limit, no number (the forecaster's own chance of this, stated with the estimate: 60%); the middle value lies beyond the limit too.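

Going by these compounds alone, compound 4, like compound 2 and compound 3, returns only a limit, so no step among them can be read in this assay. From the compounds shown here alone, whether pyridin-4-yl, pyrimidin-2-yl and pyrimidin-4-yl differ at all in this assay stays open.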